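This account rests on a few compounds, and the source may have more. Where it says the series, first, only, none or still open, it means among the compounds named here.

Measured so far in a functional assay on T47D cells (Homo sapiens) for inhibition; on this read-out lower numbers stand for stronger inhibition and higher numbers for weaker inhibition:
compound 1 `Oc1cccc(-c2cc(-c3ccccc3F)cc(-c3cccc(O)c3)n2)c1`, 4370 nM
compound 2 `Oc1cccc(-c2cc(-c3cccc(F)c3)cc(-c3cccc(O)c3)n2)c1`, 21300 nM
compound 3 `Oc1ccc(-c2cc(-c3ccccc3F)cc(-c3cccc(O)c3)n2)cc1`, 6370 nM

From compound 1 to compound 2 the change is 3-fluorophenyl in place of 2-fluorophenyl on an aromatic carbon; it made a 4.9-fold higher number from compound 1 to compound 2 (0.69 log units; beyond the scatter). Compound 3 differs from compound 1 by 4-hydroxyphenyl in place of 3-hydroxyphenyl on an aromatic carbon, with a 1.5-fold higher number from compound 1 to compound 3 (0.16 log units; within the scatter). Compound 4 `Oc1ccc(-c2cc(-c3cccc(F)c3)cc(-c3cccc(O)c3)n2)cc1` is unmeasured; it differs from compound 3 by 3-fluorophenyl in place of 2-fluorophenyl on an aromatic carbon. This is the same kind of change as from compound 1 to compound 2, but the surroundings differ: in compound 1 the place is meta to two 3-hydroxyphenyl groups, in compound 3 it is meta to a 3-hydroxyphenyl group and meta to a 4-hydroxyphenyl group. Among the compounds with values here, the expectation for compound 4 rests on the single earlier instance, a 4.9-fold higher number from compound 1 to compound 2 (0.69 log units; beyond the scatter), applied to compound 3 at 6370 nM. Compound 4 is expected to show a 4.7-fold higher number from compound 3 to compound 4 (0.67 log units; beyond the scatter) in this assay. Compound 4 is estimated at 30000 nM, likely between 12000 nM and 80000 nM.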

Compound 4, half-maximal inhibitory concentration: 3510 nM
Compound 4: the middle estimate sits 8.5-fold (0.93 log units) above what was measured, and the stated range ends above it.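

In this assay the exchange of 2-fluorophenyl for 3-fluorophenyl does not carry over from one core to the other, with a 1.8-fold lower number from compound 3 to compound 4 (0.26 log units; within the scatter) set against the earlier step: the same change on two cores in this assay, a 4.9-fold higher number (0.69 log units; beyond the scatter) from compound 1 to compound 2 and a 1.8-fold lower number (0.26 log units; within the scatter) from compound 3 to compound 4, 8.8-fold (0.95 log units) apart, beyond the scatter of two such steps

The exchange of 3-hydroxyphenyl for 4-hydroxyphenyl likewise depends on the core, with a 6.1-fold lower number from compound 2 to compound 4 (0.78 log units; beyond the scatter): the same change on two cores in this assay, a 1.5-fold higher number (0.16 log units; within the scatter) from compound 1 to compound 3 and a 6.1-fold lower number (0.78 log units; beyond the scatter) from compound 2 to compound 4, 8.8-fold (0.95 log units) apart, beyond the scatter of two such steps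

The two changes are thus not additive across these four compounds, but this one set shows neither the reason nor whether the same holds for any other group.

Still open, going by these compounds, is whether this dependence on the core persists when the fluorine gives way to an amine or a methoxy group, or a hydroxyl group to a carboxylic acid.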